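Moving the trifluoromethyl group on compound 2

A few compounds are considered here, and "the series" means these few. Any claim that something is new, unique, unknown or untested is made for them only; others in the source may bear on it.

Compound 1 `CC(O)(COc1ccccc1C(F)(F)F)C(=O)Nc1cccc(S(F)(F)(F)(F)F)c1`: 52200 nM
Compound 2 `CC1(C)C(=O)N(c2cccc(S(F)(F)(F)(F)F)c2)C(=S)N1c1ccc(C(F)(F)F)cc1`: 39800 nM

In a functional assay on DU-145 cells (Homo sapiens) for antiproliferative activity, read by propidium iodide staining, with a stated time of 96 h (on this read-out higher numbers stand for weaker inhibition and lower numbers for stronger inhibition), compound 2 gives 39800 nM. This lies within the usual scatter of compound 1, so the two values cannot be told apart. Compound 3 `CC1(C)C(=O)N(c2cccc(S(F)(F)(F)(F)F)c2)C(=S)N1c1cccc(C(F)(F)F)c1` has 3-(trifluoromethyl)phenyl in place of 4-(trifluoromethyl)phenyl on an amide-type nitrogen in a ring. Among the compounds with values here, no two measured compounds show the effect of this kind of change, so no step beyond the scatter is expected in this assay. The expected step is small: a 1.1-fold lower number from compound 2 to compound 3 (0.04 log units; within the scatter). For compound 3, the estimated value is 36000 nM, with an expected range from 13000 nM to 90000 nM.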

Compound 3, half-maximal inhibitory concentration: 100000 nM
Beside the measured number, compound 3's estimate is 2.8-fold (0.44 log units) below it, and the stated range ends below it.
By their numbers in this assay, from the lowest: compounds 2, 1 and 3 (each within the scatter of the next, the first and the last beyond it).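

Moving the trifluoromethyl group, with the same atoms joined differently, is enough to change the result in (this assay) by a modest step beyond the scatter (a 2.5-fold higher number from compound 2 to compound 3 (0.40 log units; beyond the scatter)). The earlier compounds shown here could not show that activity at this amide-type ring nitrogen depends on where the group sits on the phenyl ring. Nothing available accounts for this step. Going by these compounds, whether a nitrile or a chlorine in place of the trifluoromethyl group would show the same difference remains open. So does whether the step would recur in a core lacking the two methyl groups.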